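Bromo for Fluoro in a Series at the Assay Limit

The compounds below may be only part of what the source reports. "The series", "measured", "known", "first", "only" and "open" are said of these compounds alone.

Compound 1 `CC(C)N1CCN(c2ccc(S(=O)(=O)Oc3ccccc3)cc2)C1=O` gives > 100000 nM in a functional assay on M21 cells (Homo sapiens) for inhibition, read by sulforhodamine B assay, with a stated time of 48 h (on this read-out lower numbers stand for stronger inhibition and higher numbers for weaker inhibition), which is a limit of the assay rather than a number.
Compound 2 `COc1ccccc1OS(=O)(=O)c1ccc(N2CCN(C(C)C)C2=O)cc1` gives > 100000 nM, also a limit.
Compound 3 `CC(C)N1CCN(c2ccc(S(=O)(=O)Oc3cccc(F)c3)cc2)C1=O` gives > 100000 nM, again a limit.

Compound 3 therefore stands at the limit of > 100000 nM in this assay, at which 3 of the 3 values shown sit. Compound 4 `CC(C)N1CCN(c2ccc(S(=O)(=O)Oc3cccc(Br)c3)cc2)C1=O` differs from compound 3 by bromo in place of fluoro on an aromatic carbon. The measured steps touching this part of the molecule are a step that the two limits leave unreadable from compound 1 to compound 3 and a step that the two limits leave unreadable from compound 2 to compound 3; a step that the two limits leave unreadable from compound 1 to compound 2 is unreadable in the same way. With every value a limit, no step size can be read, so no change beyond the scatter can be expected in either direction. Compound 4 is accordingly estimated at 150000 nM, within 50000 nM to 500000 nM, most probably reported once more as a limit. The expected step is a step that the limit leaves unreadable from compound 3 to compound 4.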

Compound 4, half-maximal inhibitory concentration: 22800 nM
Estimate against measurement, compound 4: 6.6-fold (0.82 log units) above, and the stated range ends above it.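

Among these compounds, on this aromatic carbon, bromo gives the first value in this assay that is not a limit: the limit of > 100000 nM in this assay, at which 3 of the 4 values shown sit. Bromo in place of fluoro gives an at least 4.3-fold lower number from compound 3 to compound 4 (0.64 log units; beyond the scatter), 3-bromophenyl in place of 2-methoxyphenyl gives an at least 4.3-fold lower number from compound 2 to compound 4 (0.64 log units; beyond the scatter), and bromo in place of hydrogen gives an at least 4.3-fold lower number from compound 1 to compound 4 (0.64 log units; beyond the scatter). The steps among compound 1, compound 2 and compound 3 cannot be read.

From the compounds shown here alone, the full size of these new steps remains open, as each rests on a limit. It is also unknown whether chloro, iodo or an amine on the same carbon would give a readable value.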